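The source may report more compounds than this note shows. Statements on the series, on what has been measured and on what is new or still open speak of the compounds shown alone.

Compound 1 `CC1=CC[C@@H]([C@@](C)(O)CCCC(C)(C)NC(=S)N/N=C\c2ccccc2)CC1` gives 12700 nM in a functional assay on UACC-62 cells (Homo sapiens) for cytotoxicity, read by sulforhodamine B assay; a higher number here means a weaker inhibitor of growth, a lower number a stronger inhibitor of growth. Among the measured compounds shown here, compound 2 `COc1ccc(/C=N\NC(=S)NC(C)(C)CCC[C@](C)(O)[C@@H]2CC=C(C)CC2)cc1` gives 7420 nM in this assay; this is the lower of the two numbers so far, though the step of a 1.7-fold lower number from compound 1 to compound 2 (0.23 log units; within the scatter) is within the scatter, so the two compounds stand together. Compound 3 `CC1=CC[C@@H]([C@@](C)(O)CCCC(C)(C)NC(=S)N/N=C\c2ccc(Cl)cc2)CC1` differs from compound 2 by chloro in place of methoxy on an aromatic carbon. For the measured compounds named here, only the step from compound 1 to compound 2 bears on this change, and it showed no movement beyond the scatter in this assay; a similar outcome is expected here. For compound 3 the estimate is 6000 nM, between 2500 nM and 15000 nM, which is the expected step of a 1.2-fold lower number from compound 2 to compound 3 (0.09 log units; within the scatter).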

Compound 3, concentration for 50% growth inhibition: 7350 nM
For compound 3 the middle estimate is 1.2-fold (0.09 log units) below the measured one; low and high end bracket the measured number.
By their numbers in this assay, from the lowest: compounds 3, 2 and 1 (each within the scatter of the next).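

Chloro on the aromatic carbon para to a large group gives the step of a 1.0-fold lower number from compound 2 to compound 3 (0.00 log units; within the scatter) in this assay and, against hydrogen, the step of a 1.7-fold lower number from compound 1 to compound 3 (0.24 log units; within the scatter) in the same assay. Hydrogen, methoxy and chloro therefore stand together at this position, so the change from 4-methoxyphenyl to 4-chlorophenyl, which removes the oxygen, separates nothing here. No supporting measurement bears on this result.

Going by these compounds, whether an amine or a carboxylic acid at this position would move the number beyond the scatter remains open. The same holds for a longer chain there.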